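Silicon for nitrogen on the chain carbon: working notes

The source may hold more compounds than are shown below. What is called first, only, known or untested is meant among the compounds shown, and "the series" means these compounds.

compound 1 `CC(C)=CCC[C@]1(C)/C=C/[C@@H](OC(=O)C=C(C)C)[C@](C)(O)/C=C/C(=O)/C(C(=O)O)=C\C1` gives > 10000 nM (a limit of the assay, not a number)
compound 2 `CC(C)=CCC[C@]1(C)/C=C/[C@@H](OC(=O)C=C(C)C)[C@](C)(O)/C=C/C(=O)/C(CCl)=C\C1` gives 390 nM
compound 3 `CC(C)=CCC[C@]1(C)/C=C/[C@@H](OC(=O)C=C(C)C)[C@](C)(O)/C=C/C(=O)/C(CN(C(C)C)C(C)C)=C\C1` gives 750 nM

In a functional assay on SW480 cells (Homo sapiens) for antiproliferative activity, read by MTT assay, with a stated time of 48 h (a higher number here means a weaker inhibitor, a lower number a stronger inhibitor), compound 3 gives 750 nM and stands within the scatter of compound 2. Compound 1 offers only a limit for comparison. In compound 4 `CC(C)=CCC[C@]1(C)/C=C/[C@@H](OC(=O)C=C(C)C)[C@](C)(O)/C=C/C(=O)/C(C[Si](C)(C)C(C)(C)C)=C\C1` the diisopropylamino group gives way to a group carrying silicon in place of nitrogen, on a saturated chain carbon bound to a double-bonded ring carbon (a group of 7 heavy atoms (6 carbon, 1 silicon; no ring) in place of a group of 7 heavy atoms (6 carbon, 1 nitrogen; no ring), on a saturated chain carbon bound to a double-bonded ring carbon). Loss of the carboxy group gave two large steps (an at least 25-fold lower number from compound 1 to compound 2 (1.40 log units; beyond the scatter); an at least 13-fold lower number from compound 1 to compound 3 (1.12 log units; beyond the scatter)), and compound 4 also lacks that group. No step beyond the scatter is expected in this assay because a 1.9-fold higher number from compound 2 to compound 3 (0.28 log units; within the scatter) stayed within it when the group on this carbon was exchanged. The series holds no other silicon-bearing group, so the range is kept wide. The expected step is small (a 1.1-fold lower number from compound 3 to compound 4 (0.03 log units; within the scatter)). The estimate for compound 4 is 700 nM (expected range 200 nM to 3000 nM).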

Compound 4, half-maximal inhibitory concentration: 3350 nM
Estimate against measurement, compound 4: 4.8-fold (0.68 log units) below, outside the stated range (above it).
By their numbers in this assay, from the lowest: compounds 2 and 3 (each within the scatter of the next); then compound 4. At a limit, above all of these: compound 1.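

Unlike the earlier exchange on this saturated chain carbon, which stayed within the scatter, the silicon-bearing group gives a measurable loss in this assay: a 4.5-fold higher number from compound 3 to compound 4 (0.65 log units; beyond the scatter), and an 8.6-fold higher number from compound 2 to compound 4 (0.93 log units; beyond the scatter); this carbon therefore does not tolerate every group of this size. Loss of the carboxy group still leaves a lower number even with this poorer group on the carbon, with an at least 2.9-fold lower number from compound 1 to compound 4 (0.47 log units; beyond the scatter). That step is only a bound, since compound 1 stands at a limit of the assay: the limit of > 10000 nM in this assay, at which 1 of the 4 values shown sits.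

The compounds shown do not separate the entry of silicon from the loss of the hydrogen-bond acceptor counted on the diisopropylamino group. From the compounds shown here alone, how a dimethylamino group or an all-carbon chain on this carbon would read remains open.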